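A few compounds are considered here, and "the series" means these few. Any claim that something is new, unique, unknown or untested is made for them only; others in the source may bear on it.

Measured compounds:
compound 1 `C=C[C@@](C)(/C=C/c1ccc(O)cc1)CC/C=C/C(=O)c1ccccc1` — > 36600 nM
compound 2 `C=C[C@@](C)(/C=C/c1ccc(O)cc1)CC/C=C/C#N` — > 36600 nM
compound 3 `C=C[C@@](C)(/C=C/c1ccc(O)c(/C=C/C(=O)c2ccccc2)c1)CCC=C(C)C` — > 20000 nM

All three values come from an ADME assay on BJ cells (Homo sapiens) for cytotoxicity, with a stated time of 72 h; a lower number here means that less compound is needed, a higher number that more compound is needed for the effect. For compound 1 the value is a limit of the assay, not a number. For compound 2 the value is likewise a limit. For compound 3 the value is also a limit. The change from compound 1 to compound 2 is cyano in place of benzoyl on a double-bonded chain carbon bound to a double-bonded chain carbon, and the step it made, a step that the two limits leave unreadable from compound 1 to compound 2, stays unreadable because both compounds sit at the limit of > 36600 nM in this assay, at which 2 of the 3 values shown sit.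

Compound 4 `C=C[C@@](C)(/C=C/c1ccc(O)c(/C=C/C#N)c1)CCC=C(C)C` has not yet been measured in this assay. It arises from compound 3 by cyano in place of benzoyl on a double-bonded chain carbon bound to a double-bonded chain carbon, the same change as from compound 1 to compound 2, made on a different core; the difference between the core of compound 1 and the core of compound 3 is not broken down here.

Compound 4 is expected to show a step that the limit leaves unreadable from compound 3 to compound 4, since compound 3 sits at the limit of > 20000 nM in this assay, at which 1 of the 3 values shown sits, and the earlier step offers no readable size. Compound 4 is therefore estimated at 30000 nM, between 15000 nM and 80000 nM, most likely again as a limit only.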

Compound 4, half-maximal effective concentration: > 36600 nM
Compound 4: no number, only a limit; the forecaster's own chance of this, stated with the estimate: 85%; middle value at least 1.2-fold (0.08 log units) from the limit.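

In this assay, compound 3 and compound 4 each give only a limit of the assay, not a number, and the step between them cannot be read. The compounds shown leave open how much of any of them is needed for the effect, and whether cyano in place of benzoyl changes that amount at all.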